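A few compounds are considered here, and "the series" means these few. Any claim that something is new, unique, unknown or untested is made for them only; others in the source may bear on it.

Compound 1 `COC(=O)c1cc(-c2cccc(NC(=O)c3ccc(/C=C/C(=O)c4cc(OC)c(OC)c(OC)c4)cc3)c2)on1` was tested in an ADME assay on Vero cells (Chlorocebus sabaeus) for cytotoxicity, read by MTT assay, with a stated time of 72 h; on this read-out higher numbers stand for lower toxicity in this test and lower numbers for higher toxicity in this test. There compound 1 gives > 50 ug/mL, which is a limit of the assay rather than a number. Compound 2 `COC(=O)c1cc(-c2cccc(NC(=O)c3ccc(/C=C/C(=O)c4ccccc4OC)cc3)c2)on1`, which differs from compound 1 by having a 2-methoxyphenyl in place of a 3,4,5-trimethoxyphenyl on a carbonyl carbon, also sits at a limit: in this assay compound 2 gives > 40 ug/mL. The step that the two limits leave unreadable from compound 1 to compound 2 cannot be read because the limit of > 40 ug/mL in this assay, at which 1 of the 2 values shown sits, and the limit of > 50 ug/mL in this assay, at which 1 of the 2 values shown sits, are both limits. For the measured compounds named here, compound 1 thus stands only at a limit, with no number of its own, and the single neighbouring compound offers no number either.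

Compound 3 `COC(=O)c1cc(-c2cccc(NC(=O)c3ccc(/C=C/C(=O)c4ccc(F)cc4F)cc3)c2)on1` carries the change (2,4-difluorophenyl in place of 3,4,5-trimethoxyphenyl on a carbonyl carbon). Going by the values given here, the only measured step touches the same carbonyl carbon but gives no readable size, so no step beyond the scatter can be expected in this assay in either direction. Compound 3 is expected to give 50 ug/mL, with a range from 20 ug/mL to 100 ug/mL. The step of a number no higher from compound 1 to compound 3 (the limit leaves the size open) is thus estimated to be small, and the result may again be only a limit.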

Compound 3, half-maximal cytotoxic concentration: > 40 ug/mL
Compound 3 ended at the assay's limit; the forecaster's own chance of this, stated with the estimate: 65%; the middle value does not contradict the limit.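

In this assay compound 3 gives > 40 ug/mL, which is a limit of the assay and not a number. The steps from compound 1 and from compound 2 to compound 3 cannot be read, because each of these values is a limit: the limit of > 40 ug/mL in this assay, at which 2 of the 3 values shown sit.

The compounds shown leave open whether changing the group on the carbonyl carbon alters toxicity to these cells at all.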